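Thiazolylmethyl in place of benzothiazolyl on the shared core

The compounds below may be only part of what the source reports. "The series", "measured", "known", "first", "only" and "open" are said of these compounds alone.

Measured so far in an assay on isolated protein with Polyunsaturated fatty acid 5-lipoxygenase (Homo sapiens) as the target; on this read-out lower numbers stand for stronger inhibition and higher numbers for weaker inhibition:

compound 1, `COC(C)c1cc(-c2ccccc2)c2ccc(OCc3cccc(C4(O)CCOCC4)c3)cc2c1`: 1200 nM
compound 2, `N#Cc1cc(-c2ccoc2)c2ccc(OCc3cccc(C4(O)CCOCC4)c3)cc2c1`: 30 nM
compound 3, `OC1(c2cccc(COc3ccc4c(-c5ccoc5)cc(-c5nc6ccccc6s5)cc4c3)c2)CCOCC1`: a limit of the assay only, > 6000 nM

Compound 3 therefore stands at the upper limit of this assay, with no number behind it. Compound 2 gives the lowest number shown; compound 1 sits between them.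

The change from compound 3 to compound 4, `OC1(c2cccc(COc3ccc4c(-c5ccoc5)cc(Cc5nccs5)cc4c3)c2)CCOCC1`, is (1,3-thiazol-2-yl)methyl in place of 1,3-benzothiazol-2-yl on an aromatic carbon. Going by the values given here, the only measured step that touches this position is an at least 200-fold higher number from compound 2 to compound 3 (2.30 log units; beyond the scatter), which tells how a large group at this position compares with the small cyano. Among the compounds with values here, compound 4 carries at this position a group of intermediate size, so some recovery from compound 3 is plausible, but the measured value for compound 3 is only a limit, and no step reaches the middle ground.

Compound 4 is expected to give 3000 nM, within 600 nM to 15000 nM, an estimated change of an at least 2.0-fold lower number from compound 3 to compound 4 (0.30 log units; that floor lies within the scatter), with a fair chance that only a limit is reported again.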

Compound 4, half-maximal inhibitory concentration: 140 nM
Beside the measured number, compound 4's estimate is 21-fold (1.33 log units) above it; measured number below the stated range.
By their numbers in this assay, from the lowest: compound 2; then compound 4; then compound 1. At a limit, above all of these: compound 3.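

In this assay, the loss seen with 1,3-benzothiazol-2-yl does not extend to every ring-bearing group at this position, as (1,3-thiazol-2-yl)methyl in its place gives an at least 42-fold lower number from compound 3 to compound 4 (1.63 log units; beyond the scatter). Cyano still remains ahead of the new group, with a 4.7-fold higher number from compound 2 to compound 4 (0.67 log units; beyond the scatter), a far smaller penalty than an at least 200-fold higher number from compound 2 to compound 3 (2.30 log units; beyond the scatter). The first of these steps is only a floor, since compound 3 rests on a limit and not a number: the limit of > 6000 nM in this assay, at which 1 of the 4 values shown sits.

The change removes the fused six-membered ring and inserts the methyl link together, so the data do not separate these two changes. A directly attached 1,3-thiazol-2-yl or a (1,3-benzothiazol-2-yl)methyl group would address that, while an amine or a carboxylic acid at this position remains unexplored within the compounds shown.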